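Hydroxy for amino on the anilino ring of the series

This account rests on a few compounds, and the source may have more. Where it says the series, first, only, none or still open, it means among the compounds named here.

Compound 2 `N#Cc1c(Nc2ccc(N)cc2)sc2ccccc12` is tested in a functional assay on HUVEC cells (Homo sapiens), read by fluorescence and microscopy, with a stated time of 6 h, tested at 250 nM (on this read-out lower numbers stand for a stronger effect and higher numbers for a weaker effect at the one concentration tested), and gives 51%. Compound 1 `N#Cc1c(Nc2cccc(O)c2)sc2ccccc12`, which carries its hydroxy elsewhere on the same ring, gives in this assay 60%; the two numbers sit within the usual scatter of each other, so no direction can be read from them. Compound 3 `N#Cc1c(Nc2ccc(O)cc2)sc2ccccc12` differs from compound 2 by hydroxy in place of amino on an aromatic carbon. Among the compounds with values here, with no step between measured compounds to lean on, the expected step of a number 4 percentage points higher from compound 2 to compound 3 (within the scatter) is none beyond the scatter. Compound 3 is therefore estimated at 55% in this assay, within 40% to 70%.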

Compound 3, a percentage reported as activity, at one concentration (the size of the read-out at that concentration, not a potency): 2%
Compound 3: middle estimate off by 53 percentage points, on the high side; measured number outside the range, below it.
By their numbers in this assay, from the lowest: compound 3; then compounds 2 and 1 (each within the scatter of the next).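

In this assay the place para to a large group proves highly sensitive: hydroxy in place of amino gives a number 49 percentage points lower from compound 2 to compound 3 (beyond the scatter) even though the two groups match in the counts of hydrogen-bond donors and acceptors. Hydroxy alone does not settle the outcome, as compound 1, with its hydroxy elsewhere on the same ring, gives 60% here. Nothing available explains this step.

From the compounds shown here alone, whether a methoxy group or a carboxylic acid in this place would keep the low number remains open. So does the response at other concentrations.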